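The source may report more compounds than this note shows. Statements on the series, on what has been measured and on what is new or still open speak of the compounds shown alone.

Compound 3 `CCN(CC)CCCOc1ccc(C(C)=O)c(O)c1` gives 16100 nM in an assay on isolated protein for inhibition of Amine oxidase [flavin-containing] B (Homo sapiens), read by fluorescence, with a stated time of 30 min (a lower number here means a stronger inhibitor, a higher number a weaker inhibitor), the lowest of the three numbers shown, though within the scatter of both neighbours: compound 1 `CCN(CC)CCCCOc1ccc(C(C)=O)c(O)c1` gives 22200 nM and compound 2 `CCN(CCCCCCCCCCOc1ccc(C(C)=O)c(O)c1)Cc1ccccc1` gives 23400 nM. Within the data shown here, the one single-point step recorded, a 1.4-fold lower number from compound 1 to compound 3 (0.14 log units; within the scatter), stays within the scatter. Compound 4 `CCN(CCCOc1ccc(C(C)=O)c(O)c1)Cc1ccccc1` differs from compound 3 by phenyl in place of methyl on a saturated chain carbon bound to an amine nitrogen. Among the measured compounds shown here, no measured step isolates this change; compound 2 carries the same benzyl on the nitrogen but also a longer chain, and its value against compound 1 and compound 3 sits within the scatter. For compound 4 the expected step is therefore a 1.2-fold lower number from compound 3 to compound 4 (0.06 log units; within the scatter) in this assay, with no direction beyond the scatter. Compound 4 is estimated at 14000 nM, range 5000 nM to 40000 nM.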

Compound 4, half-maximal inhibitory concentration: 14900 nM
The estimate for compound 4 lay 1.1-fold (0.03 log units) below the measured number, and the stated range covers the measured number.
By their numbers in this assay, from the lowest: compounds 4, 3, 1 and 2 (each within the scatter of the next).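

In this assay, phenyl in place of methyl on a saturated chain carbon bound to an amine nitrogen now has a direct reading (a 1.1-fold lower number from compound 3 to compound 4 (0.03 log units; within the scatter)). The change, also readable as ethyl to benzyl, adds a six-membered aromatic ring at this place and leaves the number within the scatter, which compound 2, with its longer chain as well, could not isolate. Nothing available explains this flat result. As far as these compounds go, whether a pyridylmethyl or a carboxylic acid-bearing benzyl on this nitrogen would move the number beyond the scatter stays open. So does the effect of a piperidine in place of the open-chain amine.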